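From isobutoxy to allyloxy: a small swap

This account rests on a few compounds, and the source may have more. Where it says the series, first, only, none or still open, it means among the compounds named here.

Compound 1 `CC(C)c1ccc(COc2ccccc2C2CC(=O)c3ccccc3O2)cc1`: 27100 nM
Compound 2 `CC(C)COc1ccccc1C1CC(=O)c2ccccc2O1`: 36700 nM

Both values come from a functional assay on RAW264.7 cells (Mus musculus) for inhibition, read by Griess assay, with stated times of 1 h and 24 h; a higher number here means a weaker inhibitor, a lower number a stronger inhibitor. Within the data shown here, compound 2 has only one measured neighbour, and the two stand level within the scatter: a 1.4-fold higher number from compound 1 to compound 2 (0.13 log units; within the scatter).

Compound 3 `C=CCOc1ccccc1C1CC(=O)c2ccccc2O1` alters compound 2 in one place: vinyl in place of isopropyl on a saturated chain carbon bound to an oxygen on an aromatic ring. In words, this is vinyl in place of isopropyl on a saturated chain carbon bound to an oxygen on an aromatic ring, so isobutoxy becomes allyloxy.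

Among the measured compounds shown here, only the step from compound 1 to compound 2 bears on this place. It replaced 4-isopropylphenyl, a group with a ring, and did not move this assay beyond the scatter. No shift beyond the scatter is therefore expected here, in either direction. The expected step is a 1.1-fold lower number from compound 2 to compound 3 (0.06 log units; within the scatter). For compound 3 the estimate is 32000 nM, with an expected range of 16000 nM to 60000 nM.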

Compound 3, half-maximal inhibitory concentration: 37800 nM
The estimate for compound 3 lay 1.2-fold (0.07 log units) below the measured number; the range from low to high includes it.
By their numbers in this assay, from the lowest: compounds 1, 2 and 3 (each within the scatter of the next).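

In this assay, the new compound shows that vinyl can take the place of isopropyl on a saturated chain carbon bound to an oxygen on an aromatic ring with no readable shift (a 1.0-fold higher number from compound 2 to compound 3 (0.01 log units; within the scatter)). The double bond that vinyl brings therefore makes no visible difference here. The much larger 4-isopropylphenyl group of compound 1 also stands level with vinyl (a 1.4-fold higher number from compound 1 to compound 3 (0.14 log units; within the scatter)), so all three groups tried at this place fall within the scatter of one another. No measured evidence says why these groups stand level.

As far as these compounds go, all three groups are built only of carbon and hydrogen, so it remains open whether an amine or a carboxylic acid at this place would move the number beyond the scatter. Every step shown also falls at this one place, so changes to the shared core remain untested in these compounds.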